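A few compounds are considered here, and "the series" means these few. Any claim that something is new, unique, unknown or untested is made for them only; others in the source may bear on it.

Measured so far in a functional assay on SW480 cells (Homo sapiens) for cytotoxicity, read by MTT assay, with a stated time of 48 h; a lower number here means a stronger inhibitor, a higher number a weaker inhibitor:
Compound 1, `COc1cc([C@H]2C[C@]2(CO)C(=O)Nc2ccccc2Cl)cc(OC)c1OC`: 40200 nM.
Compound 2, `COc1cc([C@H]2C[C@@]2(CO)C(=O)NCc2ccc(C)cc2)cc(OC)c1OC`: a limit only, > 100000 nM.
Compound 3, `CCOC(=O)[C@@]1(C(=O)Nc2ccccc2Cl)C[C@@H]1c1cc(OC)c(OC)c(OC)c1`: 46700 nM.

Compound 3 and compound 1 lie within the usual scatter of each other, so neither is set apart from the other by the numbers at hand. The remaining entry, that of compound 2, is a limit of this assay and not a number (the limit of > 100000 nM in this assay, at which 1 of the 3 values shown sits). Compound 3 therefore stands as one of two numbers in this assay, not separated from the other.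

Compound 4 is `COc1cc([C@H]2C[C@@]2(CO)C(=O)Nc2ccccc2Cl)cc(OC)c1OC`. It differs from compound 3 in one place: hydroxymethyl in place of ethoxycarbonyl on a saturated ring carbon. Among the compounds with values here, no measured pair among the three compounds above isolates this change, so its size cannot be read from the existing numbers. Compound 4 shares its hydroxymethyl and its amide with compound 1, which gives 40200 nM, a value near that of compound 3. On that basis the change is expected to stay within the scatter, with no direction favoured. The step is expected to come to a 1.0-fold lower number from compound 3 to compound 4 (0.02 log units; within the scatter). Compound 4 is estimated at 45000 nM, with a range from 15000 nM to 130000 nM.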

Compound 4, half-maximal inhibitory concentration: > 100000 nM
Compound 4 gave a limit, no number; the forecaster's own chance of this, stated with the estimate: 30%; at least 2.2-fold (0.34 log units) between middle value and limit.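

In this assay compound 4 gives a limit and not a number, > 100000 nM, and with it the count of values shown at that limit rises: the limit of > 100000 nM in this assay, at which 2 of the 4 values shown sit.

Within the data shown here, this saturated ring carbon of the three-membered ring proves sensitive to the group it carries, since hydroxymethyl in place of ethoxycarbonyl gives an at least 2.1-fold higher number from compound 3 to compound 4 (0.33 log units; beyond the scatter), a step beyond the scatter that no earlier pair could show. It is equally sensitive to configuration, with an at least 2.4-fold higher number from compound 1 to compound 4 (0.39 log units; beyond the scatter), so hydroxymethyl retains a measurable number in this assay only as drawn in compound 1, and this second step can be assigned to the stereocentre alone: the fact that compounds 1 and 4 differ only in the configuration as drawn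

Compound 2 and compound 4 both stand as limits, and the step between them cannot be read. A carboxylic acid or an aminomethyl group on this saturated ring carbon, and ethoxycarbonyl in the configuration drawn in compound 1, lie outside the compounds shown, so it remains open whether the configuration matters as much with other groups here and which group this carbon tolerates best.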